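Replacing 4-methylpiperazin-1-yl in compound 1

The source may hold more compounds than are shown below. What is called first, only, known or untested is meant among the compounds shown, and "the series" means these compounds.

For the measured compounds named here, in an ADME assay on COS-7 cells (Chlorocebus aethiops) for cytotoxicity, read by MTT assay, with a stated time of 24 h (a lower number here means that less compound is tolerated, a higher number that more compound is tolerated), compound 1 `CCOC(=O)c1c(CN2CCN(C)CC2)nc2ccc(Cl)cc2c1-c1ccccc1` gives 35900 nM as the only number. Compound 2 `O=C(O)c1c(CNCc2ccccc2)nc2ccc(Cl)cc2c1-c1ccccc1` stands as "not determined" (no result reported) and offers no comparison. Compound 3 `CCOC(=O)c1c(CN(C)Cc2ccccc2)nc2ccc(Cl)cc2c1-c1ccccc1` carries benzyl(methyl)amino in place of 4-methylpiperazin-1-yl on a saturated chain carbon bound to an aromatic carbon. Going by the values given here, no measured step in this assay covers this change, so the expectation is weak: a modest move towards less compound tolerated, possibly no larger than the usual scatter. The estimated change is a 1.4-fold lower number from compound 1 to compound 3 (0.16 log units; within the scatter) and nothing larger is expected. For compound 3 the estimate is 25000 nM as the expected value, with 8000 nM to 80000 nM as its range.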

Compound 3, half-maximal cytotoxic concentration: 315000 nM
Estimate against measurement, compound 3: 13-fold (1.10 log units) below; the measured number lies above the stated range.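

In this assay, the step of an 8.8-fold higher number from compound 1 to compound 3 (0.94 log units; beyond the scatter) comes with benzyl(methyl)amino in place of 4-methylpiperazin-1-yl on a saturated chain carbon bound to an aromatic carbon, and it lies beyond the scatter. This position is therefore not silent: the amine carried there can move the tolerated concentration upward, at least for this one pair. No measured evidence bears on the reason for this step.

The compounds shown leave open whether the benzyl ring or the loss of the piperazine ring accounts for the step. A morpholine or a dimethylamino group at this place would help separate the two.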